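Pyrazole nitrogen substituent: methyl to hydroxyoxetanylmethyl

The compounds below may be only part of what the source reports. "The series", "measured", "known", "first", "only" and "open" are said of these compounds alone.

Compound 2 `Cc1nn(C)cc1Nc1nc(N)c2c(C#N)c(N3CCC[C@H]3C)n(C)c2n1` gives 38 nM in an assay on isolated protein for inhibition of Leucine-rich repeat serine/threonine-protein kinase 2 (Homo sapiens), read by TR-FRET and LanthaScreen, with stated times of 50 min and 30 min, in the presence of a further agent that is not named here (a higher number here means a weaker inhibitor, a lower number a stronger inhibitor), the only number shown for it. Compound 1 `Cc1nn(C2CCOC2)cc1Nc1nc(N)c2c(C#N)c(N3CCC[C@H]3C)n(C)c2n1`, the oxolanyl analogue, gives 19 nM; 44 nM (2 entries) in this assay, and with the several entries of compound 1 in this assay, 19 nM; 44 nM (2 entries) the two compounds sit within the usual scatter of each other. Compound 3 `Cc1nn(CC2(O)COC2)cc1Nc1nc(N)c2c(C#N)c(N3CCC[C@H]3C)n(C)c2n1` differs from compound 2 by 3-hydroxyoxetan-3-yl in place of hydrogen on a saturated chain carbon bound to an aromatic nitrogen. Within the data shown here, no measured pair isolates this change. The expected step is a 1.1-fold lower number from compound 2 to compound 3 (0.04 log units; within the scatter), within the scatter and without a clear direction. Compound 3 is estimated at 35 nM in this assay, range 12 nM to 100 nM.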

Compound 3, half-maximal inhibitory concentration: 57 nM
Estimate against measurement, compound 3: 1.6-fold (0.21 log units) below, and the stated range covers the measured number.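

Among these compounds, on a saturated chain carbon bound to an aromatic nitrogen, 3-hydroxyoxetan-3-yl in place of hydrogen gives the only measured step at this position in this assay: a 1.5-fold higher number from compound 2 to compound 3 (0.18 log units; within the scatter). This position therefore accepts 3-hydroxyoxetan-3-yl, with its four-membered ring, without a step beyond the scatter. Repeat entries of a single compound spread at least as widely: the several entries of compound 1 in this assay, 19 nM; 44 nM (2 entries).

On these data alone, whether a dimethylamino group or a carboxylic acid at this chain carbon would give a step beyond the scatter remains open. As far as these compounds go, a longer chain carrying the same 3-hydroxyoxetan-3-yl also remains open.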